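The source may report more compounds than this note shows. Statements on the series, on what has been measured and on what is new or still open speak of the compounds shown alone.

Compound 1 `[N-]=[N+]=NCC/C(=C(\c1ccccc1)c1ccc(OCCO)cc1)c1ccccc1` carries an azido group on its side chain. In a functional assay on MCF7 cells (Homo sapiens) for cytotoxicity, read by MTT assay, with a stated time of 48 h (on this read-out lower numbers stand for stronger inhibition and higher numbers for weaker inhibition), compound 1 reads > 100000 nM, which is a limit of the assay and not a number. For the measured compounds named here, compound 2 `NCC/C(=C(\c1ccccc1)c1ccc(OCCO)cc1)c1ccccc1` has amino in that place and gives 15900 nM, the only true number so far, so there is no other measured number to rank it against. Compound 3 `NCCOc1ccc(/C(=C(/CCN)c2ccccc2)c2ccccc2)cc1` keeps that amino group and alters a second one: amino in place of hydroxy on a saturated chain carbon, two bonds along the chain from an oxygen on an aromatic ring. Going by the values given here, only one measured step bears on this change, an at least 6.2-fold lower number from compound 1 to compound 2 (0.79 log units; beyond the scatter), and it brought in amino at a different place, so it is a loose guide pointing to a lower number in this assay. A smaller move in that direction is expected, a 2.0-fold lower number from compound 2 to compound 3 (0.30 log units; within the scatter). For compound 3 the estimated value is 8000 nM, with an expected range of 2500 nM to 25000 nM.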

Compound 3, half-maximal inhibitory concentration: 23600 nM
Compound 3: middle estimate off by 3.0-fold (0.47 log units), on the low side; measured number inside the range.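

In this assay, changing 2-hydroxyethoxy to 2-aminoethoxy gives a 1.5-fold higher number from compound 2 to compound 3 (0.17 log units; within the scatter), so at this position the two groups cannot be told apart by this read-out. The amino group that replaced azido on the side chain went with a step beyond the scatter, but the amino group here does not, so that earlier move does not carry over to this position. Compound 1 remains a limit of the assay and not a number: the limit of > 100000 nM in this assay, at which 1 of the 3 values shown sits.

On these data alone, what a carboxylic acid, a dimethylamino group or a methoxy group would read in place of the hydroxy stays open. Also open, as far as these compounds go, is whether a longer chain carrying the amino group would move the number beyond the scatter.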